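Swapping fluoro for methoxy on the benzyl ring

The source may report more compounds than this note shows. Statements on the series, on what has been measured and on what is new or still open speak of the compounds shown alone.

Among the compounds with values here, compound 2 `Nc1cc(N)c2nc(-c3ccccc3)c(NCc3ccc(F)cc3)nc2c1` holds the lower of the two numbers so far. In a functional assay on MDA-MB-231 cells (Homo sapiens) for inhibition, read by sulforhodamine B assay, with a stated time of 48 h (a higher number here means a weaker inhibitor of growth, a lower number a stronger inhibitor of growth), compound 2 gives 2140 nM, while compound 1 `COc1ccc(CNc2nc3cc(N)cc(N)c3nc2-c2ccccc2)cc1OC` gives 11200 nM in this assay. Within the data shown here, the one step between them, a 5.2-fold lower number from compound 1 to compound 2 (0.72 log units; beyond the scatter), came with the exchange of 3,4-dimethoxyphenyl for 4-fluorophenyl on the saturated chain carbon bound to the ring nitrogen.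

Compound 3 `COc1ccc(CNc2nc3cc(N)cc(N)c3nc2-c2ccccc2)cc1` has not been measured in this assay. It differs from compound 2 by methoxy in place of fluoro on an aromatic carbon. Among the measured compounds shown here, only the step from compound 1 to compound 2 bears on this change, and it moves part of the way back: one methoxy returns, though not the second, and the fluoro leaves. Since that single step a 5.2-fold lower number from compound 1 to compound 2 (0.72 log units; beyond the scatter) was modest, the return of one methoxy is expected to raise the number, but by less than that step, so a small to modest increase in this assay, a 2.1-fold higher number from compound 2 to compound 3 (0.32 log units; beyond the scatter), is expected. Compound 3 is therefore estimated at 4500 nM in this assay, within a range of 1800 nM to 12000 nM.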

Compound 3, concentration for 50% growth inhibition: 2880 nM
The estimate for compound 3 lay 1.6-fold (0.19 log units) above the measured number; low and high end bracket the measured number.
By their numbers in this assay, from the lowest: compounds 2 and 3 (each within the scatter of the next); then compound 1.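

In this assay, methoxy in place of fluoro on the aromatic carbon para to a large group gives a 1.3-fold higher number from compound 2 to compound 3 (0.13 log units; within the scatter), so the two groups cannot be told apart at this position. The step that lies beyond the scatter is a different one: a 3.9-fold lower number from compound 1 to compound 3 (0.59 log units; beyond the scatter), with hydrogen in place of methoxy on an aromatic carbon. Among these three compounds, the higher number of compound 1 therefore goes with the second methoxy that only compound 1 carries, and the earlier step need not be credited to the fluoro of compound 2. No measurement here accounts for this result.

The compounds shown leave open how far this position tolerates other groups, such as an amine, a carboxylic acid or a longer alkoxy chain in place of the methoxy of compound 3. They also leave open whether the apparent equivalence of fluoro and methoxy would hold with a chlorine or a trifluoromethyl group on this same aromatic carbon.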